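This account rests on a few compounds, and the source may have more. Where it says the series, first, only, none or still open, it means among the compounds named here.

Measured in a functional assay on HepG2 cells (Homo sapiens) for cytotoxicity, with a stated time of 72 h; a higher number here means that more compound is needed for the effect, a lower number that less compound is needed:

Compound 1 `C=C[C@@](C)(/C=C/c1ccc(OS(=O)(=O)C(F)(F)F)cc1)CCC=C(C)C`: > 52000 nM (a limit)
Compound 2 `C=C[C@@](C)(/C=C/c1ccc(OS(=O)(=O)c2ccc(C)cc2)cc1)CCC=C(C)C`: > 52000 nM (a limit)
Compound 3 `C=C[C@@](C)(/C=C/c1ccc(O)c(/C=C/C(=O)c2ccccc2)c1)CCC=C(C)C`: > 52000 nM (a limit)

Compound 3 gives > 52000 nM, which is a limit of the assay and not a number. The other two compounds stand in the same position, so the series offers (the limit of > 52000 nM in this assay, at which 3 of the 3 values shown sit).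

Compound 4 `C=C[C@@](C)(/C=C/c1ccc(O)c(/C=C/C(N)=O)c1)CCC=C(C)C` changes one group of compound 3: amino in place of phenyl on a carbonyl carbon. Put another way, benzoyl gives way to carbamoyl.

For the measured compounds named here, the only measured step, a step that the two limits leave unreadable from compound 1 to compound 2, concerns a different group, so it gives no size for this change. Compound 3 also offers no number to step from. No step beyond the scatter can therefore be argued in either direction, and compound 4 is expected to stay near the same limit. The expected change is a number no higher from compound 3 to compound 4 (the limit leaves the size open). For compound 4 the estimated value is 52000 nM, with an expected range from 20000 nM to 100000 nM.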

Compound 4, half-maximal effective concentration: > 52000 nM
Compound 4: a limit, no number (the forecaster's own chance of this, stated with the estimate: 75%); the middle value sits exactly at the limit.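

Compound 4 gives > 52000 nM, which is a limit of the assay and not a number. Compound 3 sits at the same limit, so no step can be read between compound 3 and compound 4. The compounds shown leave open how large any of these structural changes is in this assay, since all the values rest on one limit: the limit of > 52000 nM in this assay, at which 4 of the 4 values shown sit.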